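The source may report more compounds than this note shows. Statements on the series, on what has been measured and on what is new or still open speak of the compounds shown alone.

Series notes. For the measured compounds named here, compound 1 `COc1cc(OCc2cccc(COc3ccccc3)c2)c2cc(-c3cn4nc(OC)sc4n3)oc2c1` is one of three compounds measured in an ADME assay on microsomes from liver (Rattus norvegicus) for metabolic stability, with a stated time of 10 min; a higher number here means that more of the compound is left, a lower number that less of the compound is left; compound 1 gives 64%, the lowest of the three numbers. Compound 2 `COc1nn2cc(-c3cc4ccc(OCc5ccccc5)cc4o3)nc2s1` in this assay gives 68%, which lies within the scatter of compound 1, so no order between these two can be read. Compound 3 `COc1cc(OCc2ccc(OCc3ccccc3)cc2)c2cc(-c3cn4nc(OC)sc4n3)oc2c1` in this assay gives 84%, beyond the scatter above compound 1 and the furthest of the three from it. Going by the values given here, no two of the measured compounds differ in one place only, so no measured step is available to lean on.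

Compound 4 `COc1cc(OCc2cccc(OCc3ccccc3)c2)c2cc(-c3cn4nc(OC)sc4n3)oc2c1` has not yet been measured in this assay. It differs from compound 1 as follows: benzyloxy in place of phenoxymethyl on an aromatic carbon. Compound 2 and compound 3 both carry benzyloxy, so the entering group is one already present in the series, and the two values within the scatter of each other for compound 1 and compound 2 suggest no large shift. Among the compounds with values here, with no measured step of this kind, a small change is expected, within the scatter or at most just beyond it on the higher side; the expected step is a number 6 percentage points higher from compound 1 to compound 4 (within the scatter). Compound 4 is estimated at 70% in this assay, with a range from 52% to 88%.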

Compound 4, percent of the compound remaining: 76%
The estimate for compound 4 lay 6 percentage points below the measured number; low and high end bracket the measured number.
By their numbers in this assay, from the lowest: compounds 1, 2, 4 and 3 (each within the scatter of the next, the first and the last beyond it).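

For the compounds shown here, the exchange of phenoxymethyl for benzyloxy, on an aromatic carbon meta to a large group, gives a number 12 percentage points higher from compound 1 to compound 4 (beyond the scatter) in this assay and so provides the first measured step, one that lies beyond the scatter. Leaving and entering groups match in heavy atoms, in their six-membered aromatic ring, and in their hydrogen-bond donors and acceptors, and the two compounds hold the same atoms joined differently, so the number at this position can shift with no change in composition. No measurement at hand bears on why the number moves, and the step stands here as an observation only.

The compounds shown leave open how this position responds to a group of a different kind, such as an amine, a carboxylic acid or a longer chain in place of benzyloxy. Going by these compounds, whether the same exchange gives a step of similar size on another core also stays open, as it is read only once, on the core of compound 1.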